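Aryl exchange from compound 3 to compound 4

This account rests on a few compounds, and the source may have more. Where it says the series, first, only, none or still open, it means among the compounds named here.

Values in a functional assay on MCF7 cells (Homo sapiens) for cytotoxicity, read by MTT assay, with a stated time of 72 h; on this read-out higher numbers stand for weaker inhibition and lower numbers for stronger inhibition:
compound 1 `COc1cccc(/C=C2\CCC/C(=C\c3ccccc3Cl)C2=O)c1OC`: 11300 nM
compound 2 `COc1cccc(/C=C2\CCC/C(=C\c3ccccc3Br)C2=O)c1OC`: 9700 nM
compound 3 `COc1cccc(/C=C2\CCC/C(=C\c3cccc(Br)c3)C2=O)c1OC`: 11700 nM

Compound 3, at 11700 nM, cannot be separated from the other two, as all three values lie within the scatter of one another. The next structure is compound 4 `COc1ccccc1/C=C1\CCC/C(=C\c2cccc(OC)c2OC)C1=O`, which carries 2-methoxyphenyl in place of 3-bromophenyl on a double-bonded chain carbon bound to a double-bonded ring carbon.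

Two measured steps change the same place: a 1.0-fold higher number from compound 1 to compound 3 (0.02 log units; within the scatter) and a 1.2-fold higher number from compound 2 to compound 3 (0.08 log units; within the scatter). The exchange of chloro for bromo gave a 1.2-fold lower number from compound 1 to compound 2 (0.07 log units; within the scatter). All three stayed small, but none brings in a methoxy group, so the measured compounds give no direct reading of this group. In this assay, no change beyond the scatter is therefore expected, and no direction is favoured. The expected step is a 1.2-fold lower number from compound 3 to compound 4 (0.07 log units; within the scatter). For compound 4 the estimated value is 10000 nM, with an expected range from 4500 nM to 20000 nM.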

Compound 4, half-maximal inhibitory concentration: 12000 nM
Estimate against measurement, compound 4: 1.2-fold (0.08 log units) below, within the range that was stated.
By their numbers in this assay, from the lowest: compounds 2, 1, 3 and 4 (each within the scatter of the next).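

In this assay, within the data shown here, the step of a 1.0-fold higher number from compound 3 to compound 4 (0.01 log units; within the scatter) shows that the first methoxy-bearing aryl group on a double-bonded chain carbon bound to a double-bonded ring carbon stays within the scatter of the bromo-substituted aryl group it replaces. Methoxy in place of an aromatic halogen reads the same way: the bromo exchange gives a 1.2-fold higher number from compound 2 to compound 4 (0.09 log units; within the scatter) and the chloro exchange gives a 1.1-fold higher number from compound 1 to compound 4 (0.03 log units; within the scatter) in this set. This place therefore accepts 2-methoxyphenyl, with its hydrogen-bond acceptor, as well as the halogen-bearing aryl groups, with no step beyond the scatter.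

Nothing at hand accounts for how closely these values agree. From the compounds shown here alone, whether an amine or a carboxylic acid on this aryl ring would move the value beyond the scatter remains open.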